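This account rests on a few compounds, and the source may have more. Where it says the series, first, only, none or still open, it means among the compounds named here.

Measured in a functional assay on ZR-75-1 cells (Homo sapiens) for inhibition, read by sulforhodamine B assay; on this read-out higher numbers stand for weaker inhibition of growth and lower numbers for stronger inhibition of growth:
- compound 1 `COc1ccc(-c2ccc(-c3ccc(-c4nc5cc(C)ccc5[nH]4)cc3)cc2)cc1OC`: 3100 nM
- compound 2 `Cc1ccc2[nH]c(-c3ccc(-c4ccc(-c5ccc(F)cc5)cc4)cc3)nc2c1`: 35000 nM

Of these two, compound 2 has the higher number at 35000 nM, which means weaker inhibition of growth in this assay. The next compound, compound 3 `Cc1ccc2[nH]c(-c3ccc(-c4ccc(-c5ccc(OC(F)(F)F)cc5)cc4)cc3)nc2c1`, keeps everything in compound 2 except one group: trifluoromethoxy in place of fluoro on an aromatic carbon, para to a large group (trifluoromethoxy in place of fluoro on an aromatic carbon).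

Among the measured compounds shown here, only one measured step bears on this change: an 11-fold higher number from compound 1 to compound 2 (1.05 log units; beyond the scatter). That step shows that altering this outer ring can move the number a long way. Read backwards, it also shows that the one measured move away from 4-fluorophenyl gave a lower number. Still, it is a single example and involves a different group, so it supports only a cautious expectation of a smaller move in the same direction. The expected change is a 2.3-fold lower number from compound 2 to compound 3 (0.37 log units; beyond the scatter), and this estimate remains uncertain. For compound 3 the estimated value is 15000 nM, with an expected range from 4000 nM to 50000 nM.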

Compound 3, concentration for 50% growth inhibition: 2410 nM
Beside the measured number, compound 3's estimate is 6.2-fold (0.79 log units) above it; measured number outside the range, below it.
By their numbers in this assay, from the lowest: compounds 3 and 1 (each within the scatter of the next); then compound 2.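

In this assay, the aromatic carbon para to a large group proves highly sensitive to a single-group change: trifluoromethoxy in place of fluoro gives a 15-fold lower number from compound 2 to compound 3 (1.16 log units; beyond the scatter). The earlier step showed only that 3,4-dimethoxyphenyl gave a lower number than 4-fluorophenyl, but 4-(trifluoromethoxy)phenyl in place of 3,4-dimethoxyphenyl now gives a 1.3-fold lower number from compound 1 to compound 3 (0.11 log units; within the scatter), which lies within the scatter, so these two groups cannot be ranked. Two quite different replacements for 4-fluorophenyl therefore give numbers that cannot be told apart, and no measurement here explains this result.

The compounds shown leave open how a trifluoromethyl group, a chlorine atom or an amine at this same position would compare, and such groups could help show whether the oxygen, the three fluorines or both matter for the drop from compound 2 to compound 3. They also leave open whether the same swap would have a similarly large effect on a different core or in other cell lines.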